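From ethoxycarbonyl to isopropoxycarbonyl on the shared core

A few compounds are considered here, and "the series" means these few. Any claim that something is new, unique, unknown or untested is made for them only; others in the source may bear on it.

Measured so far in an ADME assay on H1-HeLa cells (Homo sapiens) for cytotoxicity, read by MTT assay, with a stated time of 3 days; a lower number here means that less compound is tolerated, a higher number that more compound is tolerated:
compound 1 `CCOC(=O)c1sc2cc(Oc3ccnc(C(=O)NC)c3)ccc2c1C` gives 50900 nM
compound 2 `CCOC(=O)c1sc2cc(Oc3ccnc(C(=O)NC)c3)ccc2c1CC` gives 35200 nM
compound 3 `CNC(=O)c1cc(Oc2ccc3cc(C(=O)OC)sc3c2)ccn1` gives > 100000 nM, a limit of the assay and not a number

Among the measured compounds shown here, compound 1 and compound 2 hold the only two numbers. Compound 4 `CNC(=O)c1cc(Oc2ccc3c(C)c(C(=O)OC(C)C)sc3c2)ccn1` is not yet measured and differs from compound 1 as follows: methyl in place of hydrogen on a saturated chain carbon bound to an oxygen next to a carbonyl group and a saturated chain carbon. The same difference reads ethoxycarbonyl to isopropoxycarbonyl.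

For the measured compounds named here, one measured step bears on this change, and only loosely. It also puts methyl in place of hydrogen, but at another place, on a saturated chain carbon bound to an aromatic carbon: a 1.4-fold lower number from compound 1 to compound 2 (0.16 log units; within the scatter). Compound 2 at 35200 nM shows no shift beyond the scatter, so none is expected for compound 4 in this assay. The estimated step is a 1.3-fold lower number from compound 1 to compound 4 (0.10 log units; within the scatter). For compound 4 the estimate is 40000 nM, with an expected range of 18000 nM to 90000 nM.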

Compound 4, half-maximal cytotoxic concentration: 18100 nM
Compound 4: the middle estimate sits 2.2-fold (0.34 log units) above what was measured; the range from low to high includes it.
By their numbers in this assay, from the lowest: compounds 4, 2 and 1 (each within the scatter of the next, the first and the last beyond it). At a limit, above all of these: compound 3.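

The change from ethoxycarbonyl to isopropoxycarbonyl gives a 2.8-fold lower number from compound 1 to compound 4 (0.45 log units; beyond the scatter) in this assay, on the shared core. Of the two single methyl additions shown, only this one lies beyond the scatter; the methyl on a saturated chain carbon bound to an aromatic carbon gave a 1.4-fold lower number from compound 1 to compound 2 (0.16 log units; within the scatter) in the same assay. The saturated chain carbon bound to an oxygen next to a carbonyl group and a saturated chain carbon is therefore a place where one added methyl moves the number, although the step is modest and rests on a single pair.

On these data alone, whether a longer chain, a cyclopropyl group or a carboxylic acid at this place would extend, reverse or remove the step remains open. No measurement shown gives a cause for the step.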